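The compounds below may be only part of what the source reports. "The series", "measured", "known", "first", "only" and "open" are said of these compounds alone.

Compounds that share a core and differ only in one end group make it possible to compare the effect of a single change. In a functional assay on MCF7 cells (Homo sapiens) for cytotoxicity, read by MTT assay, with a stated time of 72 h (a lower number here means a stronger inhibitor, a higher number a weaker inhibitor), compound 1 (`COc1cc2ncnc(Nc3ccc(F)c(Cl)c3)c2cc1NC(=O)N/N=C/c1ccc(F)cc1`) gives 35100 nM. On the same measure compound 3 (`COc1cc2ncnc(Nc3ccc(F)c(Cl)c3)c2cc1NC(=O)N/N=C/c1ccc([N+](=O)[O-])cc1`) gives 36800 nM, which puts it level with compound 1 once the usual scatter is allowed for. Compound 2 (`COc1cc2ncnc(Nc3ccc(F)c(Cl)c3)c2cc1NC(=O)N/N=C/c1ccc(C#N)cc1`) offers no help, as its entry reads "not determined" (no result reported).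

The next compound, compound 4 (`COc1cc2ncnc(Nc3ccc(F)c(Cl)c3)c2cc1NC(=O)N/N=C/c1cccc(Cl)c1Cl`), has 2,3-dichlorophenyl in place of 4-nitrophenyl on a carbon with a double bond to nitrogen.

Within the data shown here, only one measured step bears on this change. Putting nitro in place of fluoro on an aromatic carbon gave a 1.0-fold higher number from compound 1 to compound 3 (0.02 log units; within the scatter), so that swap left the number within the scatter. This is thin evidence, since that single step involved neither chlorine nor the 2,3-dichlorophenyl group. No change beyond the scatter is therefore expected in this assay, though the range must stay wide. The expected step is a 1.1-fold lower number from compound 3 to compound 4 (0.05 log units; within the scatter). Compound 4 is estimated at 33000 nM, with an expected range from 13000 nM to 80000 nM.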

Compound 4, half-maximal inhibitory concentration: 28700 nM
For compound 4 the middle estimate is 1.1-fold (0.06 log units) above the measured one; low and high end bracket the measured number.
By their numbers in this assay, from the lowest: compounds 4, 1 and 3 (each within the scatter of the next).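

In this assay, the earlier comparison covered only a swap between two groups on the phenyl ring, while this result tests a different substitution on that ring: 2,3-dichlorophenyl in place of 4-nitrophenyl on a carbon with a double bond to nitrogen gave a 1.3-fold lower number from compound 3 to compound 4 (0.11 log units; within the scatter), and 2,3-dichlorophenyl in place of 4-fluorophenyl gave a 1.2-fold lower number from compound 1 to compound 4 (0.09 log units; within the scatter). Both steps stay within the usual scatter, so 4-fluorophenyl, 4-nitrophenyl and 2,3-dichlorophenyl cannot be told apart at this position, even though the entering group differs from the other two in both its substituents and where they sit. No separate measurement is available to explain why this exchange leaves the number within the scatter.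

As far as these compounds go, all three end groups compared here are substituted phenyl rings, so it remains open whether an end group of another kind, such as an amine, a carboxylic acid or a longer alkyl chain, would also stay within the scatter in this assay. From the compounds shown here alone, it also remains open whether a change to the shared core would shift the number further than these changes to the end group have done.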